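This account rests on a few compounds, and the source may have more. Where it says the series, first, only, none or still open, it means among the compounds named here.

Of the compounds shown here, three with a shared core have been measured in an assay on HEK293 cells for positive allosteric modulation of metabotropic glutamate receptor 5 (Homo sapiens), read by FLIPR; on this read-out higher numbers stand for an effect only at larger amounts of compound and lower numbers for an effect already at smaller amounts. Compound 1 `CC1CCC(C(=O)N2CC(c3nc(-c4cccc(Cl)c4)no3)C2)CC1` gives 1500 nM. Compound 2 `O=C(N1CCC(F)CC1)N1CC(c2nc(-c3cccc(Cl)c3)no2)C1` gives 990 nM, and the step of a 1.5-fold lower number from compound 1 to compound 2 (0.18 log units; within the scatter) lies within the scatter. Compound 3 `O=S(=O)(c1ccc(F)cc1)N1CC(c2nc(-c3cccc(Cl)c3)no2)C1` returns only a limit, > 10000 nM, which is the limit of > 10000 nM in this assay, at which 1 of the 3 values shown sits. Among the two numbers, compound 2 has the lowest, with compound 1 nearest and within the scatter of it.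

Compound 4 `O=C(C1CCC1)N1CC(c2nc(-c3cccc(Cl)c3)no2)C1` differs from compound 2 by cyclobutyl in place of 4-fluoropiperidin-1-yl on a carbonyl carbon. Going by the values given here, the only measured step that bears on this position is the one from compound 1 to compound 2, an exchange of one six-membered ring for another on the carbonyl carbon, and it stayed within the scatter. Compound 3 changes a different part of the molecule and gives no number, so it offers no guide. The exchange for a smaller cyclobutyl is therefore expected to move this assay little, if at all, with a slightly higher number judged somewhat more likely than a lower one; the expected step is a 1.5-fold higher number from compound 2 to compound 4 (0.18 log units; within the scatter). Compound 4 is estimated at 1500 nM, between 600 nM and 4000 nM.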

Compound 4, half-maximal effective concentration: > 10000 nM
Compound 4 was reported as a limit; the forecaster's own chance of this, stated with the estimate: 10%; middle value at least 6.6-fold (0.82 log units) away from the limit.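

The carbonyl carbon seemed undemanding while one six-membered ring replaced another, but in this assay it proves sensitive to the group it carries: cyclobutyl in place of 4-fluoropiperidin-1-yl gives an at least 10-fold higher number from compound 2 to compound 4 (1.00 log units; beyond the scatter), and cyclobutyl in place of 4-methylcyclohexyl gives an at least 6.6-fold higher number from compound 1 to compound 4 (0.82 log units; beyond the scatter). The agreement seen between 4-methylcyclohexyl and 4-fluoropiperidin-1-yl therefore does not extend to cyclobutyl, with its four-membered ring of carbon only. The reading for compound 4 is a limit and not a number, so the full size of both steps remains unknown: the limit of > 10000 nM in this assay, at which 2 of the 4 values shown sit.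

The compounds shown leave open whether ring size alone accounts for this shift, which a cyclopentyl or an unsubstituted cyclohexyl on the same carbonyl carbon could address. They also do not tell how a morpholine or an open chain such as n-butyl would fare there.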